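Turning one stereocentre: compound 3 to compound 4

The source may report more compounds than this note shows. Statements on the series, on what has been measured and on what is new or still open speak of the compounds shown alone.

In an ADME assay on the whole organism (strain Sprague-Dawley) for metabolic stability, with Rattus norvegicus as the target (a lower number here means that the compound disappears faster, a higher number that the compound lasts longer), compound 1 (`CN[C@@H](C)c1ccc(N2CC[C@H](NS(=O)(=O)c3ccc4cc(Cl)ccc4c3)C2=O)c(F)c1`) reads 18 h and compound 2 (`CN(C)C1CCc2cc(N3CC[C@H](NS(=O)(=O)/C=C/c4ccc(Cl)s4)C3=O)ccc21`) reads 1.7 h, while compound 3 (`CN(C)[C@H]1CCc2cc(N3CC[C@H](NS(=O)(=O)c4ccc5cc(Cl)ccc5c4)C3=O)ccc21`) stands at 4.4 h in the middle of the three. Its number lies above that of compound 2 and below that of compound 1, and both gaps are beyond the usual scatter.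

Compound 4 (`CN(C)[C@@H]1CCc2cc(N3CC[C@H](NS(=O)(=O)c4ccc5cc(Cl)ccc5c4)C3=O)ccc21`) is the next to be read, and it differs from compound 3 only in configuration as drawn (the two compounds have the same atoms and bonds and differ only in configuration as drawn: 1 of 2 stereo elements differ; a stereocentre at a saturated ring carbon is drawn S in compound 3 and R in compound 4): the two compounds have the same atoms and bonds, and a stereocentre at a saturated ring carbon is drawn S in compound 3 and R in compound 4.

Among the measured compounds shown here, no two measured compounds differ in one place only, so the data give no direct reading of such a change. The expected step is none beyond the scatter, with no direction favoured (a 1.0-fold higher number from compound 3 to compound 4 (0.01 log units; within the scatter)). For the measured compounds named here, this expectation rests on compound 3 (4.4 h), the only measured compound with the same atoms and bonds as compound 4. Compound 4 is estimated at 4.5 h with 2 h to 10 h as the expected range.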

Compound 4, half-life: 3.4 h
Compound 4: the middle estimate sits 1.3-fold (0.12 log units) above what was measured; the range from low to high includes it.
By their numbers in this assay, from the lowest: compounds 2, 4 and 3 (each within the scatter of the next, the first and the last beyond it); then compound 1.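

Inverting the stereocentre at a saturated ring carbon, drawn S in compound 3 and R in compound 4, gives the first pair in the series that differs in one place only, and in this assay the reading is a 1.3-fold lower number from compound 3 to compound 4 (0.11 log units; within the scatter). At this carbon, the configuration as drawn therefore does not separate the two compounds in this assay, something that could not be read from compound 1 and compound 2, each of which differs from compound 3 in more than one place. The comparison isolates a single structural feature, with nothing else varying between the two: the fact that compounds 3 and 4 differ only in the configuration as drawn

The compounds shown leave open whether the two configurations stay this close with another group in place of the tertiary amine, such as a primary amine or a morpholine. How the sulfonyl side and the amine side each contribute to the wider spread among compound 1, compound 2 and compound 3 also remains open; no pair shown isolates either side.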